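Inverting One Stereocentre in a Urea Pair

A few compounds are considered here, and "the series" means these few. Any claim that something is new, unique, unknown or untested is made for them only; others in the source may bear on it.

Compound 2 `C[C@@H](NC(=O)Nc1cc(C(C)(C)C)ccc1C(C)(C)C)c1ccccc1` was measured in an ADME assay on the whole organism with Oryza sativa as the target, tested at 1 uM (a higher number here means a weaker effect of the compound at the concentration tested, a lower number a stronger effect), where compound 2 gives 99%. That places compound 2 level with compound 1 `C[C@H](NC(=O)Nc1ccccc1C(C)(C)C)c1ccccc1`, which in this assay gives 99%; the two stand together within the usual scatter. Compound 3 `C[C@H](NC(=O)Nc1cc(C(C)(C)C)ccc1C(C)(C)C)c1ccccc1` has not yet been measured in this assay. The change from compound 2 to compound 3 is the two compounds have the same atoms and bonds and differ only in configuration as drawn: 1 of 1 stereo elements differ; a stereocentre at a saturated chain carbon is drawn R in compound 2 and S in compound 3. Within the data shown here, no measured step of this kind exists here, and compound 2 already reads 99%, so no move beyond the scatter is expected. The expected step is no change at the digits printed from compound 2 to compound 3 (within the scatter). Compound 3 is estimated to give 99%, within 95% to 100%.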

Compound 3, a percentage reported as activity, at one concentration (the size of the read-out at that concentration, not a potency): 98%
The estimate for compound 3 lay 1 percentage points above the measured number, and the stated range covers the measured number.
By their numbers in this assay, from the lowest: compounds 3, 1 and 2 (each within the scatter of the next).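

In this assay, the configuration at the saturated chain carbon shows no effect beyond the scatter, with a number 1 percentage points lower from compound 2 to compound 3 (within the scatter). With that carbon drawn S in both compounds, the added tert-butyl also stays within the scatter, with a number 1 percentage points lower from compound 1 to compound 3 (within the scatter). The stereo comparison is a clean one, since the pair offers a single point of difference: the fact that compounds 2 and 3 differ only in the configuration as drawn

All three compounds stand together, so the shown set does not reveal which part of the structure, if any, governs this read-out. It also leaves open whether an amine or a carboxylic acid in place of a tert-butyl would shift the number beyond the scatter.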